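The compounds below may be only part of what the source reports. "The series", "measured", "known", "first", "only" and "open" are said of these compounds alone.

Among the measured compounds shown here, in a functional assay on HCT-15 cells (Homo sapiens) (a higher number here means that more compound is needed for the effect, a lower number that less compound is needed), three compounds have numbers so far. Compound 1 (`COc1cc(OC)c(C2OC(c3ccc(N)c(C)c3)=NN2C(C)=O)cc1OC`) gives 198 uM, compound 2 (`CC(=O)N1N=C(c2ccc(N(C)C)cc2)OC1c1cc(C)c(C)c(C)c1`) gives 1.5 uM, and compound 3 (`COc1cc(C2OC(c3ccc(N(C)C)cc3)=NN2C=O)cc(OC)c1OC`) gives 0.096 uM. Compound 3 therefore holds the lowest number of the three, and its gaps to both others lie beyond the scatter. No two of these compounds differ in only one place, so no measured step isolates the effect of any single group.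

Compound 4 (`COc1cc(C2OC(c3ccc(N(C)C)cc3)=NN2C(=O)CN(C)C)cc(OC)c1OC`) departs from compound 3 in one place, a carbonyl carbon whose other neighbour is an amide-type nitrogen in a ring. There, (dimethylamino)methyl stands in place of hydrogen: (dimethylamino)methyl in place of hydrogen on a carbonyl carbon. For the measured compounds named here, no measured compound carries this group, so the evidence is indirect. Compound 2 has a methyl group on that carbonyl carbon and stands at 1.5 uM, but it also differs from compound 3 elsewhere, so its value offers only a loose guide. A higher number than that of compound 3 is expected on this basis, with considerable uncertainty. The expected change is a 4.2-fold higher number from compound 3 to compound 4 (0.62 log units; beyond the scatter), an upward move probably beyond the scatter. For compound 4 the estimated value is 0.4 uM, with an expected range of 0.08 uM to 2.5 uM.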

Compound 4, concentration for half-maximal effect: 80 uM
Compound 4: the middle estimate sits 200-fold (2.30 log units) below what was measured; measured number above the stated range.
By their numbers in this assay, from the lowest: compound 3; then compound 2; then compound 4; then compound 1.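

In this assay, the carbonyl carbon whose other neighbour is an amide-type nitrogen in a ring proves highly sensitive to substitution: (dimethylamino)methyl in place of hydrogen gives an 830-fold higher number from compound 3 to compound 4 (2.92 log units; beyond the scatter), a large change and one beyond the scatter. Among the compounds shown here, this is the first step that isolates a single change, so with the rest of the structure held constant, the whole gap belongs to this one replacement of the formyl group by ((dimethylamino)methyl)carbonyl. The numbers establish the size and direction of the change at this position, but no measurement shown accounts for it, and the mechanism behind the step remains unexplained.

From the compounds shown here alone, how a methyl or methoxymethyl group on this carbonyl carbon would read on the core of compound 3 remains open, so the step cannot yet be assigned to the amine nitrogen rather than to the added carbon atoms. Also open, going by these compounds, is whether a longer chain ending in the same amine, or a carboxylic acid at this place, would give a number nearer to that of compound 3 or to that of compound 4.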